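The source may report more compounds than this note shows. Statements on the series, on what has been measured and on what is new or still open speak of the compounds shown alone.

Compound 1, `O=C(CCc1ccccc1)Nc1nc2ccccc2c(=O)s1`: 17.6 nM
Compound 2, `O=C(CCCc1ccc(Cl)c(Cl)c1)Nc1nc2ccccc2c(=O)s1`: 3440 nM

Both compounds were tested in an in vitro assay on cells for inhibition of Amine oxidase [flavin-containing] B (Homo sapiens), read by fluorescence and Amplex Red, with stated times of 30 min and 45 min; on this read-out lower numbers stand for stronger inhibition and higher numbers for weaker inhibition. Compound 2 gives the highest of the two numbers, while compound 1 gives 17.6 nM, a gap well beyond the scatter. Compound 3, `O=C(CCCc1cccc(Cl)c1)Nc1nc2ccccc2c(=O)s1`, has not been measured yet. It differs from compound 2 by hydrogen in place of chloro on an aromatic carbon. For the measured compounds named here, no step between measured compounds is available for this change, so its size is uncertain. Compound 1 carries no chloro group and gives the far lower number 17.6 nM, but it also differs in its chain. The estimated step of a 2.3-fold lower number from compound 2 to compound 3 (0.36 log units; beyond the scatter) is a modest move toward stronger inhibition, possibly within the scatter. Compound 3 is expected at 1500 nM, between 300 nM and 7000 nM.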

Compound 3, half-maximal inhibitory concentration: > 1000 nM
Compound 3 ended at the assay's limit; the forecaster's own chance of this, stated with the estimate: 5%; the middle value lies beyond the limit too.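

In this assay compound 3 gives > 1000 nM, which is a limit and not a number. The step for hydrogen in place of chloro therefore cannot be read, because the value sits at a limit: the limit of > 1000 nM in this assay, at which 1 of the 3 values shown sits. Placing 3-chlorobenzyl where phenyl stood gives an at least 56-fold higher number from compound 1 to compound 3 (1.75 log units; beyond the scatter), so keeping only one chloro group does not restore strong inhibition.

Still open, from the compounds shown here alone, is how much of this loss comes from the chain and how much from the chloro group. Going by these compounds, a plain benzyl group at this place would separate the two, and a methoxy group on the ring remains untested here as a replacement for chloro.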